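The source may hold more compounds than are shown below. What is called first, only, known or untested is meant among the compounds shown, and "the series" means these compounds.

Measured in a functional assay on PC-3 cells (Homo sapiens) for cytotoxicity, read by MTT assay, with a stated time of 72 h; a lower number here means a stronger inhibitor, a higher number a weaker inhibitor:
- compound 1 `O=C(N/N=C/c1cccc(Br)c1)Nc1cc2c(Nc3ccc(F)c(Cl)c3)ncnc2cc1O[C@H]1CCOC1`: 15500 nM
- compound 2 `COc1cc2ncnc(Nc3ccc(F)c(Cl)c3)c2cc1NC(=O)N/N=C/c1ccc(F)cc1`: 36500 nM
- compound 3 `COc1cc2ncnc(Nc3ccc(F)c(Cl)c3)c2cc1NC(=O)N/N=C/c1cccc(Br)c1`: "not active" (no number reported)

Compound 3 has no single number in this assay. It is reported only as "not active" (no number reported), so it cannot be placed numerically against the other two compounds.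

The next compound is compound 4 `COc1cc2ncnc(Nc3ccc(F)c(Cl)c3)c2cc1NC(=O)N/N=C/c1ccc([N+](=O)[O-])cc1`. The change is 4-nitrophenyl in place of 3-bromophenyl on a carbon with a double bond to nitrogen, with 4-nitrophenyl in place of 3-bromophenyl on a carbon with a double bond to nitrogen.

Without a number for compound 3, no step size can be stated. A move from no reading to a weak reading is expected, near compound 2, which gives 36500 nM. A second report of no activity remains possible.

For compound 4 the expected value is 35000 nM, with an estimated range of 12000 nM to 100000 nM.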

Compound 4, half-maximal inhibitory concentration: 32400 nM
Estimate against measurement, compound 4: 1.1-fold (0.03 log units) above; the measured number falls inside the stated range.
By their numbers in this assay, from the lowest: compound 1; then compounds 4 and 2 (each within the scatter of the next).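

In this assay nitro in place of fluoro on an aromatic carbon gives a 1.1-fold lower number from compound 2 to compound 4 (0.05 log units; within the scatter), so these two groups do not separate at this position. Compound 4 with its 4-nitrophenyl reads 32400 nM, while compound 3 with its 3-bromophenyl is reported only as not active, and that step cannot be read. No measurement bearing on a cause for these readings is available.

On these data alone, whether an amine or a carboxylic acid in place of nitro would read apart from compound 2 and compound 4 stays open. Also open, as far as these compounds go, is whether the report for compound 3 follows from the bromo group itself or from its place on the ring.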